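A few compounds are considered here, and "the series" means these few. Any claim that something is new, unique, unknown or untested is made for them only; others in the source may bear on it.

Compound 2 `Cc1ccc2[nH]c(=O)c(/C=N/O)cc2c1` carries hydroxy on the double-bonded nitrogen of the shared core. In a functional assay, read by spectrophotometry, with a stated time of 3 min (a higher number here means a weaker inhibitor, a lower number a stronger inhibitor), compound 2 gives 38900 nM, the highest of the three numbers recorded in the series. Compound 1 `Cc1ccc2[nH]c(=O)c(/C=N/c3ccccc3O)cc2c1`, with 2-hydroxyphenyl in the same position, gives 8240 nM in this assay, and compound 3 `O=c1[nH]c2ccccc2cc1/C=N/c1ccc(O)cc1`, a hydroxyphenyl analogue on a closely related core, gives 7150 nM; the values of compound 1 and compound 3 lie within the scatter of each other.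

Compound 4 `Cc1ccc2[nH]c(=O)c(/C=N/Nc3ccccc3)cc2c1` differs from compound 2 by anilino in place of hydroxy on a double-bonded nitrogen. For the measured compounds named here, the one measured step that bears on this change is a 4.7-fold higher number from compound 1 to compound 2 (0.67 log units; beyond the scatter), in which loss of the aromatic ring from the double-bonded nitrogen raised the number by a modest amount beyond the scatter. Going by the values given here, compound 4 runs the other way, restoring an aromatic ring, though attached through a nitrogen rather than directly; no measured compound tests that linkage, so the comparison is approximate. A step of about a 4.3-fold lower number from compound 2 to compound 4 (0.64 log units; beyond the scatter) is therefore expected in this assay, downward, of a size similar to the reverse of the step seen between compound 1 and compound 2. Compound 4 is estimated at 9000 nM, with a range from 3500 nM to 25000 nM.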

Compound 4, half-maximal inhibitory concentration: 8470 nM
Beside the measured number, compound 4's estimate is 1.1-fold (0.03 log units) above it, within the range that was stated.
By their numbers in this assay, from the lowest: compounds 3, 1 and 4 (each within the scatter of the next); then compound 2.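

In this assay, anilino in place of hydroxy on a double-bonded nitrogen gives a 4.6-fold lower number from compound 2 to compound 4 (0.66 log units; beyond the scatter), so the series now holds a second comparison in which hydroxy alone on this nitrogen carries the higher number. The earlier compounds shown here showed this only for a directly attached 2-hydroxyphenyl, whereas anilino brings its six-membered aromatic ring through a nitrogen, and the two groups cannot be told apart here, with a 1.0-fold higher number from compound 1 to compound 4 (0.01 log units; within the scatter); at this level of resolution, the change of linkage and the absence of the hydroxy on the aromatic ring of compound 4 leave no readable mark on the number. Nothing measured here accounts for either step.

Open, from the compounds shown here alone, is whether the aromatic ring itself matters or any larger group on this nitrogen would serve, a question that cyclohexyl or a simple alkyl chain in place of anilino would address. Also open, going by these compounds, is how an amine or a carboxylic acid carried on the anilino ring would move the number on the shared core.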